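This account rests on a few compounds, and the source may have more. Where it says the series, first, only, none or still open, it means among the compounds named here.

Measured set:
- compound 1, `O=C(c1ccccc1)N1CCC(NCCSC(c2ccc(F)cc2)c2ccc(F)cc2)CC1`, in an assay on membranes from striatum (strain Sprague-Dawley) for displacement of a labelled ligand from sodium-dependent dopamine transporter (Rattus norvegicus), read by scintillation counting, with a stated time of 120 min (a higher number here means a weaker inhibitor, a lower number a stronger inhibitor), compound 1 gives 4.51 nM
- compound 2, `Fc1ccc(C(SCCNC2CCN(Cc3cc4ccccc4o3)CC2)c2ccc(F)cc2)cc1`, compound 2 gives 120 nM
- compound 3, `CC(C)(C)CN1CCC(NCCSC(c2ccc(F)cc2)c2ccc(F)cc2)CC1`, compound 3 gives 279 nM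

Compound 3 stands at the highest number of the three: the step of a 62-fold higher number from compound 1 to compound 3 (1.79 log units; beyond the scatter) is large, and the step of a 2.3-fold higher number from compound 2 to compound 3 (0.37 log units; beyond the scatter) is modest, so compound 3 is the weakest inhibitor of the measured set by its steps to both others.

Compound 4, `O=C(c1ccccc1F)N1CCC(NCCSC(c2ccc(F)cc2)c2ccc(F)cc2)CC1`, is the next member. The change from compound 3 is (2-fluorophenyl)carbonyl in place of neopentyl on an amine nitrogen in a ring. The step that bears on it most directly is a 62-fold higher number from compound 1 to compound 3 (1.79 log units; beyond the scatter), run in reverse: putting a benzoyl back on that ring nitrogen in place of the neopentyl gave the large fall in number seen in compound 1. The step of a 27-fold higher number from compound 1 to compound 2 (1.43 log units; beyond the scatter) points the same way, the acyl on the ring nitrogen going with the lowest number. Among the compounds with values here, no measured pair shows what the fluorine on the (2-fluorophenyl)carbonyl adds. A large step down in this assay is therefore expected, of about a 47-fold lower number from compound 3 to compound 4 (1.67 log units; beyond the scatter), landing compound 4 near compound 1. Estimate for compound 4: 6 nM, range 2 nM to 25 nM.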

Compound 4, inhibition constant: 46.1 nM
Compound 4: middle estimate off by 7.7-fold (0.89 log units), on the low side; measured number above the stated range.
By their numbers in this assay, from the lowest: compound 1; then compound 4; then compound 2; then compound 3.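

In this assay, the acyl group on the ring nitrogen does not by itself set the number, since fluoro in place of hydrogen on an aromatic carbon of the benzoyl gives a 10-fold higher number from compound 1 to compound 4 (1.01 log units; beyond the scatter). The (2-fluorophenyl)carbonyl group still compares favourably with both non-acyl groups on that nitrogen, but the steps are only modest: a 6.1-fold lower number from compound 3 to compound 4 (0.78 log units; beyond the scatter) against neopentyl and a 2.6-fold lower number from compound 2 to compound 4 (0.42 log units; beyond the scatter) against (1-benzofuran-2-yl)methyl. No available evidence accounts for the large fluoro step.

As far as these compounds go, whether chloro, methyl or methoxy in place of that fluoro would give a step of similar size remains open. So does the part played by the carbonyl itself, which a plain benzyl or a benzenesulfonyl group on the ring nitrogen would help to separate from that of the aromatic ring.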